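This account rests on a few compounds, and the source may have more. Where it says the series, first, only, none or still open, it means among the compounds named here.

Compound 1, `C/C=C/C(=O)N1CCCC(n2nc(-c3ccc(Oc4ccccc4)cc3)cc2C(=O)OCC)C1`: 26500 nM
Compound 2, `C=CC(=O)Nc1ccc(Cn2nc(-c3ccc(Oc4ccccc4)cc3)cc2C(=O)O)cc1`: > 60000 nM

In a functional assay on JeKo-1 cells (Homo sapiens) for inhibition, read by luminescence and CellTiter-Glo, with a stated time of 72 h (a lower number here means a stronger inhibitor, a higher number a weaker inhibitor), compound 1 gives 26500 nM. Compound 2 returns > 60000 nM, which is a limit of the assay and not a number, so for compound 2 only a limit is known. Compound 2 therefore stands at the limit of > 60000 nM in this assay, at which 1 of the 2 values shown sits. For the measured compounds named here, with one of the two measured compounds at a limit and the two structures differing in more than one place, no step between measured compounds can be given in this assay, and the two values show only that compound 1 gives a number where compound 2 does not.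

Compound 3, `O=C(CCl)Nc1ccc(Cn2nc(-c3ccc(Oc4ccccc4)cc3)cc2C(=O)O)cc1`, has not yet been measured in this assay. It differs from compound 2 in a single place: chloromethyl in place of vinyl on a carbonyl carbon. The estimate for compound 3 means a step that the limit leaves unreadable from compound 2 to compound 3, which is expected to be none beyond the usual scatter, with compound 3 most likely returning a limit again. Compound 3 is accordingly estimated at 70000 nM, within a range from 25000 nM to 200000 nM.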

Compound 3, half-maximal inhibitory concentration: 2500 nM
The estimate for compound 3 lay 28-fold (1.45 log units) above the measured number; measured number below the stated range.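

In this assay, for the compounds shown here, the exchange of vinyl for chloromethyl on a carbonyl carbon whose other neighbour is an amide-type nitrogen gives an at least 24-fold lower number from compound 2 to compound 3 (1.38 log units; beyond the scatter), the first comparison that can be read across a single change, and it shows that this position strongly affects the read-out while the rest of the structure stays the same. The two groups have the same number of heavy atoms, neither has a ring, and neither carries hydrogen-bond donors or acceptors, so these counts do not separate them, whereas the chlorine and the double bond outside aromatic rings do differ. Compound 2 has a limit and not a number, so the full size of the step stays unknown: the limit of > 60000 nM in this assay, at which 1 of the 3 values shown sits.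

The compounds shown do not tell whether the chlorine itself is needed, since a plain methyl or a bromomethyl group on the same carbonyl carbon does not appear among them. They also leave open whether a longer chain carrying the chlorine, or an amine in place of the carboxylic acid on the shared core, would keep the number seen for compound 3.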